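A few compounds are considered here, and "the series" means these few. Any claim that something is new, unique, unknown or untested is made for them only; others in the source may bear on it.

Measured compounds:
compound 1 `CC1CCN(c2nc(C(F)(F)F)ccc2CNC(=O)Nc2cccc3c2ccc(=O)n3C)CC1` — 2.59 nM
compound 2 `CC1CCN(c2nc(C(F)(F)F)ccc2CNC(=O)Nc2cccc3ccc(=O)[nH]c23)CC1` — 441 nM

In an assay on CHO cells for antagonist activity at transient receptor potential cation channel subfamily V member 1 (Homo sapiens) (on this read-out lower numbers stand for stronger inhibition and higher numbers for weaker inhibition), compound 2 gives 441 nM, the highest of the two numbers seen so far. In this assay compound 1 gives 2.59 nM, a markedly lower number, and the gap between the two values lies well beyond the scatter of repeated measurements. Only what the two values show can be said of this pair; nothing further is recorded for it.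

Compound 3 `CC1CCN(c2nc(C(F)(F)F)ccc2CNC(=O)Nc2ccc3ccc(=O)[nH]c3c2)CC1` has not been measured. It differs from compound 2 in this way: a group of 11 heavy atoms (9 carbon, 1 nitrogen, 1 oxygen; one six-membered aromatic ring of carbon only, one six-membered aromatic ring with 1 hetero atom) in place of a group of 11 heavy atoms (9 carbon, 1 nitrogen, 1 oxygen; one six-membered aromatic ring of carbon only, one six-membered aromatic ring with 1 hetero atom), on an amide-type nitrogen, a group of 11 heavy atoms (9 carbon, 1 nitrogen, 1 oxygen; one six-membered aromatic ring of carbon only, one six-membered aromatic ring with 1 hetero atom) in place of a group of 11 heavy atoms (9 carbon, 1 nitrogen, 1 oxygen; one six-membered aromatic ring of carbon only, one six-membered aromatic ring with 1 hetero atom), on an amide-type nitrogen. For the measured compounds named here, no measured pair shows this kind of rearrangement, so its effect in this assay is unknown. A step of modest size is expected, probably toward a higher number, and possibly not beyond the scatter: a 2.3-fold higher number from compound 2 to compound 3 (0.36 log units; beyond the scatter) is the expected move. Compound 3 is estimated at 1000 nM, within a range of 150 nM to 6000 nM.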

Compound 3, inhibition constant: 0.83 nM
For compound 3 the middle estimate is 1200-fold (3.08 log units) above the measured one; measured number outside the range, below it.
By their numbers in this assay, from the lowest: compound 3; then compound 1; then compound 2.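

In this assay, rejoining the same atoms on the amide-type nitrogen gives a 530-fold lower number from compound 2 to compound 3 (2.73 log units; beyond the scatter); the group that leaves and the group that enters have the same heavy-atom composition, the same ring types and the same counts of hydrogen-bond donors and acceptors. For the compounds shown here, this is the first single-place step, and it shows that at this place the read-out depends strongly on how the group is joined, so those shared counts do not set the number. Nothing at hand bears on why this rearrangement produces so large a step.

Still open, on these data alone, is whether the number in this assay would hold with a fluorine atom or a methoxy group added to the group that enters, or with an amine in place of its carbonyl oxygen. A single step also cannot show whether the same rearrangement would have a similar effect with other changes elsewhere on the shared core, such as a nitrile in place of the trifluoromethyl group.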